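Methyl for hydrogen on the aromatic ring of compound 2

The compounds below may be only part of what the source reports. "The series", "measured", "known", "first", "only" and "open" are said of these compounds alone.

Of the compounds shown here, two sharing one core have been measured in an assay on lysosomes for inhibition of Maltase-glucoamylase (Homo sapiens), read by spectrophotometry, tested at 1000 uM; a higher number here means more inhibition at the concentration tested (going by the name of the read-out), a lower number less inhibition. Compound 1 `O[C@@H]1[C@@H](O)CN[C@H]1c1ccc(-c2ccccc2)cc1` gives 15.6% in this assay . Compound 2 `O[C@@H]1[C@@H](O)CN[C@H]1c1ccccc1` gives 24.6%, the higher of the two numbers, though the step of a number 9 percentage points higher from compound 1 to compound 2 (within the scatter) is within the scatter, so the two compounds cannot be ranked against each other. Compound 3 `Cc1ccc([C@@H]2NC[C@H](O)[C@H]2O)cc1` is not yet measured in this assay . Its difference from compound 2 is methyl in place of hydrogen on an aromatic carbon. Among the compounds with values here, the only step that bears on this change is the one from compound 1 to compound 2, where phenyl in place of hydrogen at the same aromatic carbon produced no shift beyond the scatter. A methyl at that carbon is therefore expected to leave the number essentially unchanged, with a step of a number 2.6 percentage points lower from compound 2 to compound 3 (within the scatter). For compound 3 the estimate in this assay is 22%, within a range from 8% to 36%.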

Compound 3, a percentage reported as inhibition, at one concentration (the size of the read-out at that concentration, not a potency): 4.8%
The estimate for compound 3 lay 17.2 percentage points above the measured number; the whole stated range lies above it.
By their numbers in this assay, from the lowest: compound 3; then compounds 1 and 2 (each within the scatter of the next).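

In this assay, this aromatic carbon, para to a group of 7 heavy atoms, proved sensitive to substitution: methyl in place of hydrogen gave a number 19.8 percentage points lower from compound 2 to compound 3 (beyond the scatter), a shift that phenyl in place of hydrogen had not produced. Methyl in place of phenyl at the same carbon gave a number 10.8 percentage points lower from compound 1 to compound 3 (beyond the scatter), so the numbers do not follow the order hydrogen, methyl, phenyl, with the methyl compound alone lowest while the hydrogen and phenyl compounds cannot be ranked against each other. Nothing available explains why methyl stands apart from the other two groups. As far as these compounds go, whether an ethyl group, a methoxy group or a fluorine at this carbon would fall with methyl or stay with hydrogen and phenyl remains open. Also open, from the compounds shown here alone, is whether a methyl on another carbon of the aromatic ring would lower the number as well.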